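Benzothiazolyl semicarbazone series: amine swap on the benzylic carbon

The compounds below may be only part of what the source reports. "The series", "measured", "known", "first", "only" and "open" are said of these compounds alone.

Measured so far:
compound 1 `CCN(CC)Cc1ccc2nc(NC(=O)N/N=C/c3c[nH]c4ccccc34)sc2c1` gives 3140 nM in a functional assay on NCI-H460 cells (Homo sapiens) for cytotoxicity, read by MTT assay, with a stated time of 72 h; on this read-out higher numbers stand for weaker inhibition and lower numbers for stronger inhibition
compound 2 `CC1CCN(Cc2ccc3nc(NC(=O)N/N=C/c4cn(Cc5ccc(C(C)(C)C)cc5)c5ccccc45)sc3c2)CC1` gives 3370 nM in this assay

Compound 2 carries the larger number of the two, but compound 1 sits only a small way off, and the gap between the two falls inside the usual scatter of repeated runs; the two cannot be ranked on these data.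

Compound 3 `CCN(CC)Cc1ccc2nc(NC(=O)N/N=C/c3cn(Cc4ccc(C(C)(C)C)cc4)c4ccccc34)sc2c1` is not yet measured. It differs from compound 2 in one place: diethylamino in place of 4-methylpiperidin-1-yl on a saturated chain carbon bound to an aromatic carbon. The rest of the structure, including the substituted indole and the shared core, is kept. Compound 1 already carries the diethylamino group, and its number in this assay is close to that of compound 2, so the change is expected to produce no step beyond the scatter, with a 1.0-fold lower number from compound 2 to compound 3 (0.01 log units; within the scatter) near zero.

Compound 3 is therefore estimated at 3300 nM in this assay, with a range from 1500 nM to 7000 nM.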

Compound 3, half-maximal inhibitory concentration: 1670 nM
Compound 3: the middle estimate sits 2.0-fold (0.30 log units) above what was measured; low and high end bracket the measured number.
By their numbers in this assay, from the lowest: compounds 3, 1 and 2 (each within the scatter of the next).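

In this assay, the swap to diethylamino on a saturated chain carbon bound to an aromatic carbon, now read with the 4-(tert-butyl)benzyl group in place, gives a 2.0-fold lower number from compound 2 to compound 3 (0.30 log units; within the scatter) and so does not separate the two amines on these data. For the compounds shown here, with diethylamino held fixed, 4-(tert-butyl)benzyl in place of hydrogen on an aromatic nitrogen gives a 1.9-fold lower number from compound 1 to compound 3 (0.27 log units; within the scatter) and is the first single-place reading of that change, which also stays inside the scatter. No independent measurement is available to interpret either step.

On these data alone, whether dimethylamino or morpholin-4-yl on the same saturated chain carbon would give a step beyond the scatter remains open. Also open, as far as these compounds go, is how an unsubstituted benzyl group on the aromatic nitrogen would read against compound 1 and compound 3.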